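Adding an acetamido group to compound 3

This account rests on a few compounds, and the source may have more. Where it says the series, first, only, none or still open, it means among the compounds named here.

Of the compounds shown here, three have so far been tested in an ADME assay on Vero cells (Chlorocebus sabaeus) for cytotoxicity; on this read-out higher numbers stand for lower toxicity in this test and lower numbers for higher toxicity in this test. Compound 1 `c1ccc(-c2nn3cnnc3s2)c(OCCC2CCOCC2)c1` gives > 50000 nM, which is a limit of the assay and not a number. Compound 2 `c1ccc(-c2nc3ccncc3s2)c(OCCC2CCOCC2)c1` gives > 50000 nM, again a limit. Compound 3 `c1ccc(Oc2ncccc2-c2nc3ccncc3s2)cc1`, the starting point here, gives > 50000 nM, also a limit. Compound 3 therefore stands with the other two at the limit of > 50000 nM in this assay, at which 3 of the 3 values shown sit.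

Compound 4 `CC(=O)Nc1ccc(Oc2ncccc2-c2nc3ccncc3s2)cc1` has not yet been measured. It differs from compound 3 in one place, (acetamido in place of hydrogen on an aromatic carbon). An acetamido group takes the place of a hydrogen on an aromatic carbon, in a six-membered aromatic ring of carbon only, para to a large group.

Among the compounds with values here, no two measured compounds differ in just one place, so no measured step can guide this prediction. The expectation rests on compound 3, whose reading of > 50000 nM is a limit. No shift beyond the usual scatter is expected in this assay, so no direction is predicted, and the estimated change is a number no higher from compound 3 to compound 4 (the limit leaves the size open). For compound 4, the expected half-maximal cytotoxic concentration is an estimated 50000 nM, within a range of 20000 nM to 100000 nM.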

Compound 4, half-maximal cytotoxic concentration: > 50000 nM
Compound 4 ended at the assay's limit (the forecaster's own chance of this, stated with the estimate: 75%); the middle value sits exactly at the limit.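

In this assay, compound 3 and compound 4 both give readings that are limits of the assay and not numbers, so no step can be read between them: the limit of > 50000 nM in this assay, at which 4 of the 4 values shown sit.

The compounds shown leave open whether acetamido in place of hydrogen changes the cytotoxicity at all, and at what concentration any of them would harm the cells.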